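A Fluoro-to-Hydrogen Step Repeated on a Second Analogue

The compounds below may be only part of what the source reports. "The series", "measured", "known", "first", "only" and "open" are said of these compounds alone.

Of the compounds shown here, three have so far been measured in a functional assay on HepG2 cells (Homo sapiens) for antiproliferative activity, read by MTT assay, with a stated time of 72 h; a higher number here means a weaker inhibitor, a lower number a stronger inhibitor. Compound 1 `O=C(N/N=C/c1ccc([N+](=O)[O-])cc1)Nc1ccc(Oc2ccnc3[nH]ccc23)c(F)c1` gives 3030 nM. Compound 3 `O=C(N/N=C/c1ccc([N+](=O)[O-])cc1)Nc1ccc(Oc2ccnc3[nH]ccc23)cc1` gives 4620 nM in this assay; the change from compound 1 to compound 3 is hydrogen in place of fluoro on an aromatic carbon, and it made a 1.5-fold higher number from compound 1 to compound 3 (0.18 log units; within the scatter). Compound 2 `COc1ccc(/C=N/NC(=O)Nc2ccc(Oc3ccnc4[nH]ccc34)c(F)c2)c(OC)c1OC` gives 2990 nM in this assay; how the core of compound 2 differs from the core of compound 1 is not broken down here, and the values of compound 2 and compound 1 sit within the scatter of each other, as do those of compound 2 and compound 3.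

Compound 4 `COc1ccc(/C=N/NC(=O)Nc2ccc(Oc3ccnc4[nH]ccc34)cc2)c(OC)c1OC` has not yet been measured. It differs from compound 2 by hydrogen in place of fluoro on an aromatic carbon, the same change as that from compound 1 to compound 3, at a place described in the same words. Resting on compound 2 at 2990 nM and on the step of a 1.5-fold higher number from compound 1 to compound 3 (0.18 log units; within the scatter), the step from compound 2 to compound 4 in this assay is expected to be a 1.5-fold higher number from compound 2 to compound 4 (0.17 log units; within the scatter). Compound 4 is therefore estimated at 4400 nM, with a likely range from 2400 nM to 8500 nM.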

Compound 4, half-maximal inhibitory concentration: 2960 nM
Compound 4: middle estimate off by 1.5-fold (0.17 log units), on the high side, within the range that was stated.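

In this assay, for the compounds shown here, hydrogen in place of fluoro on an aromatic carbon gave a 1.0-fold lower number from compound 2 to compound 4 (0.00 log units; within the scatter), so on this core the change produced no step that can be told from the usual scatter. Set beside the earlier step, the result gives no sign that the two cores respond differently to the change: the same change on two cores in this assay, a 1.5-fold higher number (0.18 log units; within the scatter) from compound 1 to compound 3 and a 1.0-fold lower number (0.00 log units; within the scatter) from compound 2 to compound 4, 1.5-fold (0.19 log units) apart, within the scatter of two such steps This is agreement between two small steps on two cores only; it does not show that the change would be equally small on any other core, and it gives no step size that could be carried further with confidence.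

The compounds shown leave open whether another group on that aromatic carbon, such as chloro, methyl or an amine, would move the number beyond the scatter. As far as these compounds go, it also remains open whether the fluoro-to-hydrogen step would stay this small if the nitro or methoxy groups gave way to a carboxylic acid or a longer chain.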